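The source may hold more compounds than are shown below. What is called first, only, known or untested is meant among the compounds shown, and "the series" means these compounds.

The series shares the core of compound 1 `CCOC(=O)CNc1nc(Nc2cccc(OC)c2)ncc1[N+](=O)[O-]`, which in a functional assay on A549 cells (Homo sapiens) for antiproliferative activity, read by MTT assay, with a stated time of 48 h (on this read-out lower numbers stand for stronger inhibition and higher numbers for weaker inhibition), gives 36100 nM. Compound 3 `CCOC(=O)CNc1nc(Nc2ccccc2)ncc1[N+](=O)[O-]` returns only a limit in this assay, > 100000 nM. Within the data shown here, the one measured step is an at least 2.7-fold higher number from compound 1 to compound 3 (0.44 log units; beyond the scatter), a loss on removing a methoxy. Compound 2 `CCOC(=O)CN(Cc1ccccc1)c1nc(NCc2cccc(OC)c2)ncc1[N+](=O)[O-]` also returns only a limit in this assay, > 100000 nM. That is the limit of > 100000 nM in this assay, at which 2 of the 3 values shown sit. Compound 4 `CCOC(=O)CN(Cc1ccccc1)c1nc(Nc2cc(OC)c(OC)c(OC)c2)ncc1[N+](=O)[O-]` differs from compound 2 by 3,4,5-trimethoxyphenyl in place of 3-methoxybenzyl on a nitrogen on an aromatic ring. Among the measured compounds shown here, no measured step covers this change; only the step from compound 1 to compound 3 offers a guide, and compound 2 standing at a limit leaves the size of any step open. A gain is nonetheless expected, an at least 3.3-fold lower number from compound 2 to compound 4 (0.52 log units; beyond the scatter). Compound 4 is therefore estimated at 30000 nM, within 8000 nM to 100000 nM.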

Compound 4, half-maximal inhibitory concentration: > 100000 nM
Compound 4: a limit, no number; the forecaster's own chance of this, stated with the estimate: 35%; middle value at least 3.3-fold (0.52 log units) away from the limit.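

No step can be read from compound 2 to compound 4, as each gives a limit and not a number in this assay: the limit of > 100000 nM in this assay, at which 3 of the 4 values shown sit.

As far as these compounds go, whether 3,4,5-trimethoxyphenyl in place of 3-methoxybenzyl on a nitrogen on an aromatic ring changes the activity at all stays open.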